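The source may report more compounds than this note shows. Statements on the series, on what has been measured and on what is new or still open speak of the compounds shown alone.

Series notes: the three measured compounds share one core, differing only in the amide-linked aryl portion. Compound 1 `COc1cc(-c2nn(-c3cccc(NC(=O)c4cccc(C(F)(F)F)c4)c3)cc2-c2ccncc2)ccc1Cl` carries a trifluoromethyl-substituted phenyl on the carbonyl carbon; in a functional assay on NCI-H226 cells (Homo sapiens) for inhibition, read by sulforhodamine B assay, with a stated time of 48 h (a lower number here means that less compound is tolerated, a higher number that more compound is tolerated), compound 1 gives > 50000 nM, which is a limit of the assay, not a number. Compound 2 `COc1cc(-c2nn(-c3cccc(NC(=O)c4ccc(Cl)c(C(F)(F)F)c4)c3)cc2-c2ccncc2)ccc1Cl` adds chloro in place of hydrogen on an aromatic carbon; in this assay compound 2 gives > 32500 nM, again a limit. Compound 3 `COc1cc(-c2nn(-c3cccc(NC(=O)Nc4ccc(Cl)c(C(F)(F)F)c4)c3)cc2-c2ccncc2)ccc1Cl` replaces that aryl with the corresponding arylamino group, making a urea; in this assay compound 3 gives > 32500 nM, also a limit. Compound 3 therefore stands at a limit, as do both other values shown, two sitting at the limit of > 32500 nM in this assay, at which 2 of the 3 values shown sit, and one at the limit of > 50000 nM in this assay, at which 1 of the 3 values shown sits.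

The measured steps a step that the two limits leave unreadable from compound 1 to compound 2, a step that the two limits leave unreadable from compound 1 to compound 3 and a step that the two limits leave unreadable from compound 2 to compound 3 are all unreadable in size because both ends are limits, so none gives a readable direction.

Compound 4 `COc1cc(-c2nn(-c3cccc(NC(=O)c4ccccc4)c3)cc2-c2ccncc2)ccc1Cl` differs from compound 3 by phenyl in place of (4-chloro-3-(trifluoromethyl)phenyl)amino on a carbonyl carbon. Among the measured compounds shown here, no measured step bears readably on this change. Given that every neighbour of compound 4 sits at a limit, compound 4 is expected to sit at a limit as well, with an estimated step that the limit leaves unreadable from compound 3 to compound 4. Compound 4 is estimated at 50000 nM, within 15000 nM to 150000 nM.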

Compound 4, concentration lethal to 50% of the cells: > 100000 nM
Compound 4 was reported as a limit (the forecaster's own chance of this, stated with the estimate: 80%); middle value at least 2.0-fold (0.30 log units) from the limit.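

In this assay compound 4 gives > 100000 nM, which is a limit of the assay and not a number. Among the compounds shown here, with compound 1, compound 2, compound 3 and compound 4 all at limits, no step among them can be read. The compounds shown leave open how far these four actually differ, and whether any change on the carbonyl carbon gives a value that is not a limit.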